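The source may hold more compounds than are shown below. What is called first, only, known or untested is meant among the compounds shown, and "the series" means these compounds.

Measured compounds in an ADME assay on the whole organism (Macaca fascicularis) for pharmacokinetics, read by LC-MS, using cassette dosing, at a dose of 1 mg/kg by the oral route; on this read-out lower numbers stand for lower exposure and higher numbers for higher exposure at the dose given:
compound 1 `CCCCN(c1nc2c(C(=O)NC)cccc2o1)[C@H](C)c1ccc(-c2ccccc2-c2nnn[nH]2)cc1` gives 19.7 nM;
compound 2 `CCCCN(c1nc2c(-c3nccn3C)cccc2o1)[C@H](C)c1ccc(-c2ccccc2-c2nnn[nH]2)cc1` gives 154 nM;
compound 3 `CCCCN(c1nc2c(CO)cccc2o1)[C@H](C)c1ccc(-c2ccccc2-c2nnn[nH]2)cc1` gives 20.7 nM.

Compound 3 stands second highest of the three numbers in this assay. Its nearest neighbour is compound 1, and the two lie within the scatter of each other, as a 1.1-fold higher number from compound 1 to compound 3 (0.02 log units; within the scatter) shows. Compound 2 stands furthest from it: a 7.4-fold lower number from compound 2 to compound 3 (0.87 log units; beyond the scatter) is beyond the scatter, and so is the matching step from compound 1, a 7.8-fold higher number from compound 1 to compound 2 (0.89 log units; beyond the scatter).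

Compound 4 `CCCCN(c1nc2c(-c3ccccn3)cccc2o1)[C@H](C)c1ccc(-c2ccccc2-c2nnn[nH]2)cc1` has not yet been measured. It differs from compound 3 in one place: pyridin-2-yl in place of hydroxymethyl on an aromatic carbon. Two of the measured steps bear on this change. In each of them an aromatic heterocycle entered or left the same carbon of the shared core, and each time the number moved by a modest amount beyond the scatter, upward when the heterocycle entered and downward when it left. Pyridin-2-yl is not 1-methyl-1H-imidazol-2-yl, so the size of the shift carries real uncertainty, but the direction is expected to be the same: compound 4 is estimated to show a higher number than compound 3 in this assay, a step of a 3.4-fold higher number from compound 3 to compound 4 (0.53 log units; beyond the scatter). Compound 4 is therefore expected to give about 70 nM, within a range from 20 nM to 250 nM.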

Compound 4, maximal plasma concentration: 124 nM
For compound 4 the middle estimate is 1.8-fold (0.25 log units) below the measured one; low and high end bracket the measured number.
By their numbers in this assay, from the lowest: compounds 1 and 3 (each within the scatter of the next); then compounds 4 and 2 (each within the scatter of the next).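

In this assay, pyridin-2-yl on this aromatic carbon shows that the rise seen earlier is not tied to 1-methyl-1H-imidazol-2-yl alone: a second aromatic heterocycle also gives a number beyond the scatter of the hydroxymethyl group, a 6.0-fold higher number from compound 3 to compound 4 (0.78 log units; beyond the scatter), and of the methylcarbamoyl group, a 6.3-fold higher number from compound 1 to compound 4 (0.80 log units; beyond the scatter). Against 1-methyl-1H-imidazol-2-yl itself the exchange gives a 1.2-fold lower number from compound 2 to compound 4 (0.09 log units; within the scatter), which lies within the scatter, so the two heterocycles cannot be told apart here. The four compounds therefore fall into two pairs, with the heterocycles of compound 2 and compound 4 above the open-chain groups of compound 1 and compound 3, no compound goes against this split, and nothing given here accounts for it.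

From the compounds shown here alone, whether a hetero atom in the ring matters, or a ring of any kind would do, remains open; a phenyl group, a saturated morpholine ring or a simple amine on this carbon would each bear on that. Going by these compounds, it also remains open whether the same split would hold with a ring placed on another carbon of the shared core.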